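Chloro placed differently on the benzyl group of compound 3

The source may report more compounds than this note shows. Statements on the series, on what has been measured and on what is new or still open speak of the compounds shown alone.

Three members of the series have numbers in a functional assay on MCF7 cells (Homo sapiens) for inhibition, read by MTT assay, with a stated time of 72 h; on this read-out higher numbers stand for weaker inhibition of growth and lower numbers for stronger inhibition of growth. Compound 1 `CC(C)(C)c1ccc(CNCCCNS(=O)(=O)c2cc(C(F)(F)F)cc(C(F)(F)F)c2)cc1` gives 2100 nM. Compound 2 `O=S(=O)(NCCCNCc1ccc(Cl)c(Cl)c1)c1cc(C(F)(F)F)cc(C(F)(F)F)c1` gives 2400 nM, and compound 3 `O=S(=O)(NCCCNCc1cccc(Cl)c1)c1cc(C(F)(F)F)cc(C(F)(F)F)c1` gives 2600 nM. Compound 3 carries the highest of the three numbers, but every gap among them sits within the scatter: a 1.1-fold higher number from compound 1 to compound 2 (0.06 log units; within the scatter), a 1.2-fold higher number from compound 1 to compound 3 (0.09 log units; within the scatter), a 1.1-fold higher number from compound 2 to compound 3 (0.03 log units; within the scatter).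

Compound 4 `O=S(=O)(NCCCNCc1ccc(Cl)cc1)c1cc(C(F)(F)F)cc(C(F)(F)F)c1` is unmeasured. Relative to compound 3 the change is 4-chlorophenyl in place of 3-chlorophenyl on a saturated chain carbon bound to an amine nitrogen. Going by the values given here, no measured step moves a chloro from one ring position to another; the steps that touch this part of the structure either exchange one substituted phenyl for another or remove a chloro, and none of them reaches beyond the scatter. On that basis the step of no change at the digits printed from compound 3 to compound 4 (within the scatter) is expected to be none beyond the scatter in this assay. Compound 4 is therefore estimated at 2600 nM in this assay, with a range from 1300 nM to 5200 nM.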

Compound 4, concentration for 50% growth inhibition: 2400 nM
The estimate for compound 4 lay 1.1-fold (0.03 log units) above the measured number; low and high end bracket the measured number.
By their numbers in this assay, from the lowest: compounds 1, 2, 4 and 3 (each within the scatter of the next).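

In this assay, going by these compounds alone, moving the chloro (step: a 1.1-fold lower number from compound 3 to compound 4 (0.03 log units; within the scatter)) gives the direct reading of chloro placement on this ring that the earlier compounds lacked, and that reading stays within the scatter. Compound 4 also sits within the scatter of its other two neighbours, with hydrogen in place of chloro on an aromatic carbon (no change at the digits printed from compound 2 to compound 4 (within the scatter)) and chloro in place of tert-butyl on an aromatic carbon (a 1.1-fold higher number from compound 1 to compound 4 (0.06 log units; within the scatter)), so none of the four benzyl groups shown separates from the others on this read-out. Nothing available bears on why these numbers stay so close.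

Still open, from the compounds shown here alone, is whether any change on the benzyl ring moves the number beyond the scatter, such as a nitrile or a carboxylic acid in place of the chloro. The compounds shown also leave untested what a longer chain between the sulfonamide and the amine would do, since all four share the same chain.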